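Methyl on the core nitrogen: a step without a precedent

This account rests on a few compounds, and the source may have more. Where it says the series, first, only, none or still open, it means among the compounds named here.

Compound 1 `O=C(Nc1ccc(Oc2ccnc3[nH]ccc23)cc1)c1nn(-c2ccc(Cl)c(F)c2)ccc1=O`: 5240 nM
Compound 2 `O=C(Nc1ccc(Oc2ccnc3[nH]ccc23)cc1)c1nn(-c2ccc(Cl)c(C(F)(F)F)c2)ccc1=O`: 1320 nM
Compound 3 `O=C(Nc1ccc(Oc2ccnc3[nH]ccc23)c(F)c1)c1nn(-c2ccc(Cl)c(F)c2)ccc1=O`: 9610 nM

In a functional assay on HepG2 cells (Homo sapiens) for cytotoxicity, read by MTT assay, with a stated time of 72 h (a lower number here means a stronger inhibitor, a higher number a weaker inhibitor), compound 1 gives 5240 nM, the second highest of the three numbers. Its nearest neighbour is compound 3, where the fluoro in place of hydrogen on an aromatic carbon brought a 1.8-fold higher number from compound 1 to compound 3 (0.26 log units; within the scatter), a change too small to separate the two. Going by the values given here, its furthest neighbour is compound 2, where the trifluoromethyl in place of fluoro on an aromatic carbon brought a 4.0-fold lower number from compound 1 to compound 2 (0.60 log units; beyond the scatter), the only step here that clearly stands out.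

Compound 4 `Cn1ccc2c(Oc3ccc(NC(=O)c4nn(-c5ccc(Cl)c(F)c5)ccc4=O)cc3)ccnc21` differs from compound 1 in one place: methyl in place of hydrogen on an aromatic nitrogen. Both measured steps sit on the outer aromatic rings, not on the fused core, so neither bears directly on this change; they only show that small additions to the shared core's neighbours move this assay little, with compound 3 as the nearest case. Among the compounds with values here, with no step touching the core nitrogen to lean on, the expected change from compound 1 to compound 4 is a 1.4-fold higher number from compound 1 to compound 4 (0.16 log units; within the scatter), that is, nothing beyond the scatter. Compound 4 is therefore estimated at 7500 nM in this assay, in a range from 2500 nM to 25000 nM.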

Compound 4, half-maximal inhibitory concentration: > 60000 nM
Compound 4: no number, only a limit; the forecaster's own chance of this, stated with the estimate: 10%; middle value at least 8.0-fold (0.90 log units) from the limit.
By their numbers in this assay, from the lowest: compound 2; then compounds 1 and 3 (each within the scatter of the next). At a limit, above all of these: compound 4.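

A single methyl on the aromatic nitrogen of the five-membered ring brings an at least 11-fold higher number from compound 1 to compound 4 (1.05 log units; beyond the scatter) in this assay, so this position of the shared core responds far more sharply than anything seen so far. The earlier changes on the outer aromatic rings, a 4.0-fold lower number from compound 1 to compound 2 (0.60 log units; beyond the scatter) and a 1.8-fold higher number from compound 1 to compound 3 (0.26 log units; within the scatter), all left the hydrogen on that nitrogen in place, so they gave no sign of how much depends on it. Compound 4 carries a limit and not a number, so its step has a floor but no measured size: the limit of > 60000 nM in this assay, at which 1 of the 4 values shown sits.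

Methyl alone cannot separate the loss of the hydrogen from the arrival of the added carbon, and an ethyl group or a longer chain on the same nitrogen would show whether the size of the group changes the outcome. As far as these compounds go, it also remains open whether methyl on that nitrogen would bring a similar step with the trifluoromethyl of compound 2 in place of the fluoro.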